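Aryl variation on the shared core: compound 2 to compound 3

The source may hold more compounds than are shown below. What is called first, only, known or untested is meant among the compounds shown, and "the series" means these compounds.

Compound 1, `Brc1cn2ccnc2c(-c2ccc3ncn(C4CCCCC4)c3c2)n1`: in a functional assay on T47D cells (Homo sapiens) for inhibition, read by sulforhodamine B assay, with a stated time of 48 h, tested at 10 uM (a higher number here means more inhibition at the concentration tested (going by the name of the read-out), a lower number less inhibition), compound 1 gives 49.7%.
Compound 2, `O=Cc1ccc(-c2cn3ccnc3c(-c3ccc4ncn(C5CCCCC5)c4c3)n2)cc1`: in this assay compound 2 gives 98%.

Among the compounds with values here, compound 2 holds the higher of the two numbers measured so far, and the single step known, a number 48.3 percentage points higher from compound 1 to compound 2 (beyond the scatter), runs toward it. Compound 3, `c1csc(-c2cn3ccnc3c(-c3ccc4ncn(C5CCCCC5)c4c3)n2)c1`, is not yet measured. It differs from compound 2 by thiophen-2-yl in place of 4-formylphenyl on an aromatic carbon. Within the data shown here, the one step that bears on this change is the step from compound 1 to compound 2, which shows that putting 4-formylphenyl on that aromatic carbon in place of bromo raised inhibition by a large margin. Thiophen-2-yl keeps an aromatic ring at the same place but carries no formyl, and nothing measured separates the ring from the formyl. Some loss against compound 2 is therefore expected, yet well short of the full step back to bromo. For compound 3 the expected step is a number 18 percentage points lower from compound 2 to compound 3 (beyond the scatter). Compound 3 is estimated at 80%, within 50% to 100%.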

Compound 3, a percentage reported as inhibition, at one concentration (the size of the read-out at that concentration, not a potency): 70.3%
Compound 3: the middle estimate sits 9.7 percentage points above what was measured, and the stated range covers the measured number.
By their numbers in this assay, from the lowest: compound 1; then compound 3; then compound 2.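

Notes on this position: in this assay, thiophen-2-yl on this aromatic carbon gives a number 20.6 percentage points higher from compound 1 to compound 3 (beyond the scatter), so the gain over bromo is not confined to the 4-formylphenyl group. The same aromatic carbon also separates the two aryl groups, with a number 27.7 percentage points lower from compound 2 to compound 3 (beyond the scatter), so an aromatic ring here does not by itself reach the level of compound 2. No measurement on hand gives a reason for either step.

The change from 4-formylphenyl to thiophen-2-yl alters the ring and removes the formyl in one move, so the compounds shown cannot assign the difference to either feature. Plain phenyl would address that question, and a phenyl bearing an amine or a carboxylic acid in place of the formyl would test how far that group can vary.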